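Esterifying the Acid Tail of Compound 2

A few compounds are considered here, and "the series" means these few. Any claim that something is new, unique, unknown or untested is made for them only; others in the source may bear on it.

Three measured compounds share one core and differ only in the group on an aromatic carbon. Compound 1 `CC(C)N(Cc1cccc(OCCCCCC(=O)O)c1)C(=O)c1ccc(-c2cccc(-c3ccccc3)c2)cc1` carries a phenyl there, compound 2 `CC(C)COc1cccc(-c2ccc(C(=O)N(Cc3cccc(OCCCCCC(=O)O)c3)C(C)C)cc2)c1` an isobutoxy, and compound 3 `CC(C)N(Cc1cccc(OCCCCCC(=O)O)c1)C(=O)c1ccc(-c2cccc(Cl)c2)cc1` a chloro. In an ADME assay on HEK293 cells (Homo sapiens) for cytotoxicity, read by CellTiter-Glo and resazurin assay, with a stated time of 72 h (on this read-out higher numbers stand for an effect only at larger amounts of compound and lower numbers for an effect already at smaller amounts), compound 1 gives only a limit, > 26000 nM. In this assay compound 2 likewise gives only a limit, > 26000 nM. Compound 3 too gives only a limit, > 21900 nM. Compound 2 thus stands at a limit, and so do the two other values, which sit at the limit of > 26000 nM in this assay, at which 2 of the 3 values shown sit, and (the limit of > 21900 nM in this assay, at which 1 of the 3 values shown sits). The steps a step that the two limits leave unreadable from compound 1 to compound 2, a step that the two limits leave unreadable from compound 2 to compound 3 and a step that the two limits leave unreadable from compound 1 to compound 3 are all of unreadable size.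

Compound 4 `CCOC(=O)CCCCCOc1cccc(CN(C(=O)c2ccc(-c3cccc(OCC(C)C)c3)cc2)C(C)C)c1` differs from compound 2 by ethyl in place of hydrogen on an oxygen next to a carbonyl group. Among the compounds with values here, no measured step touches this part of the molecule, and the steps from compound 2 could not be sized. The expected step is a number no higher from compound 2 to compound 4 (the limit leaves the size open), none readable beyond the scatter. Compound 4 is therefore estimated at 26000 nM, within a range from 12000 nM to 60000 nM, and most likely will again be reported only as a limit.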

Compound 4, half-maximal effective concentration: > 26000 nM
Compound 4 was reported as a limit (the forecaster's own chance of this, stated with the estimate: 75%); the middle value lies on the limit itself.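

In this assay compound 2 and compound 4 both give only a limit, and the step between them cannot be read. The compounds shown leave open whether ethoxycarbonyl in place of carboxy changes this read-out at all, and none of the four compounds gives an actual number.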